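Flipping One Stereocentre in a Cytotoxicity Screen

This account rests on a few compounds, and the source may have more. Where it says the series, first, only, none or still open, it means among the compounds named here.

Compounds measured so far:
- compound 1, `Cc1nc([C@@H](CCN)NC(=O)C(=O)Nc2ccc(Cl)cc2)sc1CO`, giving >= 46600 nM in an ADME assay on TZM cells (Homo sapiens) for cytotoxicity, read by XTT assay, with a stated time of 3 days; on this read-out higher numbers stand for lower toxicity in this test and lower numbers for higher toxicity in this test
- compound 2, `O=C(N[C@@H](CC1CCNCC1)c1nc(CO)cs1)c1ccc(-c2ccc(C(F)(F)F)cc2)[nH]1`, giving > 40000 nM in this assay

Compound 2 does not have a number here but a limit: its reading sits at the limit of > 40000 nM in this assay, at which 1 of the 2 values shown sits, so the test reached its top concentration without finding a half-maximal effect. Compound 1 is in the same position, with its own limit at the limit of >= 46600 nM in this assay, at which 1 of the 2 values shown sits. Nothing shown separates the two, and neither can be called less toxic than the other.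

Compound 3, `O=C(N[C@H](CC1CCNCC1)c1nc(CO)cs1)c1ccc(-c2ccc(C(F)(F)F)cc2)[nH]1`, is the mirror partner of compound 2 at one position: the two compounds have the same atoms and bonds and differ only in configuration as drawn: 1 of 1 stereo elements differ; a stereocentre at a saturated chain carbon is drawn S in compound 2 and R in compound 3. Going by the values given here, because compound 2 stands at the limit of > 40000 nM in this assay, at which 1 of the 2 values shown sits, there is no measured step to build on. A change of configuration alone is expected to move this assay by nothing beyond the usual scatter, and the step from compound 2 to compound 3 is estimated as a number no higher from compound 2 to compound 3 (the limit leaves the size open). Compound 3 is therefore expected to give about 40000 nM, within 20000 nM to 80000 nM, most likely again reported only as a limit.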

Compound 3, half-maximal cytotoxic concentration: > 40000 nM
Compound 3: a limit, no number (the forecaster's own chance of this, stated with the estimate: 85%); the middle value sits exactly at the limit.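

Compound 2 and compound 3 both end in a limit rather than a number in this assay, so no step can be read between these mirror partners: the limit of > 40000 nM in this assay, at which 2 of the 3 values shown sit. As far as these compounds go, whether the two differ in toxicity at higher concentrations stays open.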